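One Hydroxy Group Added on Two Different Cores

A few compounds are considered here, and "the series" means these few. Any claim that something is new, unique, unknown or untested is made for them only; others in the source may bear on it.

Of the compounds shown here, three have so far been measured in a functional assay on HT-29 cells (Homo sapiens) for cytotoxicity, read by MTT assay, with a stated time of 6 days; on this read-out higher numbers stand for an effect only at larger amounts of compound and lower numbers for an effect already at smaller amounts. Compound 1 `O=c1cc(-c2ccc([N+](=O)[O-])cc2)oc2cc(O)ccc12` gives 6.95 ug/mL in this assay. Compound 2 `O=c1cc(-c2ccc([N+](=O)[O-])cc2)oc2c(O)c(O)ccc12` differs from compound 1 in one place, (hydroxy in place of hydrogen on an aromatic carbon), and in this assay compound 2 gives 3.46 ug/mL. The step this change made is a 2.0-fold lower number from compound 1 to compound 2 (0.30 log units; within the scatter), so the two values cannot be told apart with confidence. Compound 3 `COc1cc(-c2cc(=O)c3ccc(O)cc3o2)cc(OC)c1O[Si](C)(C)C(C)(C)C` carries a different core; in this assay compound 3 gives 1 ug/mL, the lowest of the three numbers, and its distance from compound 2 and from compound 1 is beyond the scatter in both cases. How the core of compound 3 differs from the core of compound 1 is not broken down here.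

Compound 4 `COc1cc(-c2cc(=O)c3ccc(O)c(O)c3o2)cc(OC)c1O[Si](C)(C)C(C)(C)C` has not yet been measured in this assay. It differs from compound 3 by hydroxy in place of hydrogen on an aromatic carbon. Among the compounds with values here, the surroundings of the place are described in the same words for both pairs, so the change from compound 3 to compound 4 is the same change as the one from compound 1 to compound 2. In this assay compound 4 is therefore expected to show a 1.7-fold lower number from compound 3 to compound 4 (0.22 log units; within the scatter), an expectation that rests on a 2.0-fold lower number from compound 1 to compound 2 (0.30 log units; within the scatter) and on the value of compound 3, 1 ug/mL. Because the earlier step of a 2.0-fold lower number from compound 1 to compound 2 (0.30 log units; within the scatter) lay within the scatter, the estimate for compound 4 is kept close to compound 3. In this assay compound 4 is expected to give about 0.6 ug/mL, most likely between 0.25 ug/mL and 1.5 ug/mL.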

Compound 4, concentration for half-maximal effect: 0.34 ug/mL
Beside the measured number, compound 4's estimate is 1.8-fold (0.25 log units) above it; measured number inside the range.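

In this assay, putting hydroxy in place of hydrogen on an aromatic carbon gives a 2.9-fold lower number from compound 3 to compound 4 (0.47 log units; beyond the scatter), a modest step that stands clear of the scatter, whereas the same change on the core of compound 1 stayed within it. Even so, the two steps cannot be told apart, so in this small set the change carries from the core of compound 1 to the core of compound 3 without a detectable difference in size: the same change on two cores in this assay, a 2.0-fold lower number (0.30 log units; within the scatter) from compound 1 to compound 2 and a 2.9-fold lower number (0.47 log units; beyond the scatter) from compound 3 to compound 4, 1.5-fold (0.17 log units) apart, within the scatter of two such steps. Within the data shown here, this does not show that the step is fixed in size or that it would hold on any further core, as it rests on only two pairs, one of which cannot be separated from the scatter when read alone, and the numbers give no reason for the lower value of compound 4.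

The compounds shown leave open whether another group at the same place, such as an amine, a carboxylic acid or a longer chain, would give a step of similar size. They also leave open whether hydroxy would behave the same way on a third core, or at another aromatic carbon of these two.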